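The compounds below may be only part of what the source reports. "The series", "measured", "known", "first", "only" and "open" are said of these compounds alone.

Two compounds in the series have numbers in a functional assay on UACC-62 cells (Homo sapiens) for antiproliferative activity, read by sulforhodamine B assay, with a stated time of 48 h (on this read-out lower numbers stand for stronger inhibition and higher numbers for weaker inhibition), so far. Compound 1 `COc1ccc(C(=O)Nc2cccc(-c3ccnc4c(NC(C)=O)cccc34)c2)cc1OC` gives 560 nM in this assay. Compound 2 `Nc1cccc2c(-c3cccc(NC(=O)Nc4cc(C(F)(F)F)cc(C(F)(F)F)c4)c3)ccnc12` gives 1800 nM, the highest of the two numbers and beyond the scatter from compound 1; the two differ in more than one place, so no single change is read from that pair. Compound 3 `CC(=O)Nc1cccc2c(-c3cccc(NC(=O)Nc4cc(C(F)(F)F)cc(C(F)(F)F)c4)c3)ccnc12` carries acetyl in place of hydrogen on a nitrogen on an aromatic ring. Among the measured compounds shown here, no measured pair shows this step alone, so the expectation rests on the pattern only loosely: a modest drop in number is expected, a 2.0-fold lower number from compound 2 to compound 3 (0.30 log units; within the scatter). Compound 3 is estimated at 900 nM, with a range of 350 nM to 2500 nM.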

Compound 3, half-maximal inhibitory concentration: 10600 nM
Beside the measured number, compound 3's estimate is 12-fold (1.07 log units) below it; measured number outside the range, above it.
By their numbers in this assay, from the lowest: compound 1; then compound 2; then compound 3.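

Among the compounds shown here, this is the first single-place change that can be read. In this assay, acetyl in place of hydrogen on a nitrogen on an aromatic ring weakens inhibition, giving a 5.9-fold higher number from compound 2 to compound 3 (0.77 log units; beyond the scatter), with the rest of the molecule unchanged. No evidence at hand accounts for this loss. As far as these compounds go, whether a methyl, a methanesulfonyl or a longer acyl chain on this nitrogen behaves like acetyl remains open. Also open, from the compounds shown here alone, is whether amino to acetamido has the same effect in the setting of compound 1.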